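The compounds below may be only part of what the source reports. "The series", "measured", "known", "first", "only" and "open" are said of these compounds alone.

Measured in an ADME assay on HEK293 cells (Homo sapiens) for cytotoxicity, read by CellTiter-Glo and resazurin assay, with a stated time of 72 h; a higher number here means that more compound is needed for the effect, a lower number that less compound is needed:
- compound 1 `CC(C)N(Cc1cccc(OCCCCCC(=O)O)c1)C(=O)c1ccc(-c2ccc3c(c2)OCCO3)cc1`: > 21900 nM, a limit of the assay.
- compound 2 `COc1cc(OC)cc(-c2ccc(C(=O)N(Cc3cccc(OCCCCCC(=O)O)c3)C(C)C)cc2)c1`: > 26000 nM, likewise a limit of the assay.

Within the data shown here, compound 2 sits at a limit in this assay; the only other value shown is also a limit. The step that the two limits leave unreadable from compound 1 to compound 2 therefore cannot be sized. Compound 3 `CC(C)N(Cc1cccc(OCCCCCC(=O)O)c1)C(=O)c1ccc(-c2cccc(OC(F)(F)F)c2)cc1` differs from compound 2 by 3-(trifluoromethoxy)phenyl in place of 3,5-dimethoxyphenyl on an aromatic carbon. Among the measured compounds shown here, the only measured step that touches this position is unreadable, so no direction is indicated. Compound 3 is expected to remain at a limit in this assay, estimated at 30000 nM with a range of 8000 nM to 100000 nM. The expected step is a step that the limit leaves unreadable from compound 2 to compound 3.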

Compound 3, half-maximal effective concentration: > 26000 nM
Compound 3: a limit, no number (the forecaster's own chance of this, stated with the estimate: 80%); the middle value does not contradict the limit.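

In this assay, among these compounds, compound 3 stands at a limit, as do compound 1 and compound 2, so no step among the three can be read. The compounds shown leave open whether these three groups on the shared core differ at all in this assay.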